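Hydroxy for chloro on two related cores in paw edema

A few compounds are considered here, and "the series" means these few. Any claim that something is new, unique, unknown or untested is made for them only; others in the source may bear on it.

Measured compounds:
compound 1 `N#Cc1c(Cl)nc(SCC(=O)Nn2c(COc3ccc(Cl)cc3Cl)nc3ccccc3c2=O)nc1-c1ccc(Cl)cc1` — 68.4%
compound 2 `N#Cc1c(Cl)nc(SCC(=O)Nn2c(COc3ccc(Cl)cc3Cl)nc3ccccc3c2=O)nc1-c1ccc(O)cc1` — 73.7%
compound 3 `N#Cc1c(Nc2ccc(Cl)cc2)nc(SCC(=O)Nn2c(COc3ccc(Cl)cc3Cl)nc3ccccc3c2=O)nc1-c1ccccc1` — 59.7%

The three compounds were tested in a functional assay on the whole organism (strain albino) for inhibition, with Rattus norvegicus as the target, read by paw edema, with stated times of 1 h and 3 h, at a dose of 100 mg/kg by the oral route; on this read-out lower numbers stand for a weaker effect and higher numbers for a stronger effect at the one dose given. Compound 1 and compound 2 share one core and differ by hydroxy in place of chloro on an aromatic carbon; this gave a number 5.3 percentage points higher from compound 1 to compound 2 (within the scatter). Compound 3 carries a different core, and the difference between the two cores is not broken down here. Compound 3 gives 59.7%, which lies within the scatter of compound 1 but beyond it relative to compound 2.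

Compound 4 `N#Cc1c(Nc2ccc(O)cc2)nc(SCC(=O)Nn2c(COc3ccc(Cl)cc3Cl)nc3ccccc3c2=O)nc1-c1ccccc1` is not yet measured. It differs from compound 3 by hydroxy in place of chloro on an aromatic carbon, the same change as that made from compound 1 to compound 2, at a place described in the same words. For the measured compounds named here, the one precedent, a number 5.3 percentage points higher from compound 1 to compound 2 (within the scatter), stayed within the scatter, so compound 4 is expected to sit close to compound 3, with an estimated step of a number 5.3 percentage points higher from compound 3 to compound 4 (within the scatter). For compound 4 the estimate is 65%, expected to fall between 52% and 78%.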

Compound 4, a percentage reported as inhibition, in the whole organism at one dose (the size of the read-out at that dose, not a potency): 59.7%
For compound 4 the middle estimate is 5.3 percentage points above the measured one; measured number inside the range.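

In this assay, hydroxy in place of chloro on an aromatic carbon gave no change at the digits printed from compound 3 to compound 4 (within the scatter). Set beside the earlier result, the change reads alike on the two cores: the same change on two cores in this assay, a number 5.3 percentage points higher (within the scatter) from compound 1 to compound 2 and no change at the digits printed (within the scatter) from compound 3 to compound 4, 5.3 percentage points apart, within the scatter of two such steps Neither step can be told from the usual scatter, so the two cores agree only in showing no clear effect of this change; they do not show that it raises or lowers the effect on either core, and two cores cannot establish a rule for the whole series, especially as the change is 4-chlorophenyl to 4-hydroxyphenyl on one core and (4-chlorophenyl)amino to (4-hydroxyphenyl)amino on the other.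

The compounds shown leave open whether a different group on that aromatic carbon, such as an amine, a methoxy group or a carboxylic acid, would give a step beyond the scatter on either core. They also leave open whether the two cores would still read alike with such a group in place.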